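This account rests on a few compounds, and the source may have more. Where it says the series, first, only, none or still open, it means among the compounds named here.

In a functional assay on CHO-K1 cells for antagonist activity at transient receptor potential cation channel subfamily V member 1 (Homo sapiens), read by FLIPR (on this read-out lower numbers stand for stronger inhibition and higher numbers for weaker inhibition), compound 2 `CC(C(=O)NCc1ccc(C(F)(F)F)nc1NCc1ccc(Cl)cc1)c1ccc(NS(C)(=O)=O)c(F)c1` gives 414 nM, the lowest of the two numbers measured. Compound 1 `CC(C(=O)NCc1ccc(C(F)(F)F)nc1Nc1ccccc1)c1ccc(NS(C)(=O)=O)c(F)c1` gives 1400 nM, and a 3.4-fold lower number from compound 1 to compound 2 (0.53 log units; beyond the scatter). Compound 3 `CC(C(=O)NCc1ccc(C(F)(F)F)nc1N(C)c1ccccc1)c1ccc(NS(C)(=O)=O)c(F)c1` changes compound 2 by methyl(phenyl)amino in place of (4-chlorobenzyl)amino on an aromatic carbon. Among the compounds with values here, this removes the 4-chlorobenzyl group that brought the gain from compound 1 to compound 2 and places a methyl group on the nitrogen instead; the measured compounds give no step for adding such a methyl group. Compound 3 is therefore expected to return to roughly the level of compound 1, so a 3.6-fold higher number from compound 2 to compound 3 (0.56 log units; beyond the scatter) is estimated. The estimate for compound 3 is 1500 nM, with a range from 400 nM to 6000 nM.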

Compound 3, half-maximal inhibitory concentration: 57.4 nM
Compound 3: the middle estimate sits 26-fold (1.42 log units) above what was measured; measured number below the stated range.
By their numbers in this assay, from the lowest: compound 3; then compound 2; then compound 1.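

In this assay a methyl on the nitrogen gives a 24-fold lower number from compound 1 to compound 3 (1.39 log units; beyond the scatter) and shows that the hydrogen on this nitrogen is not needed for strong inhibition in this series. Methyl(phenyl)amino in place of (4-chlorobenzyl)amino gives a 7.2-fold lower number from compound 2 to compound 3 (0.86 log units; beyond the scatter) and shows that the 4-chlorobenzyl group is not needed for a low number at this position. Nothing available explains the size of either step. Still open, from the compounds shown here alone, is whether an ethyl group on the same nitrogen keeps this gain, and whether a methyl adds to the 4-chlorobenzyl group of compound 2 in the same way.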